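The compounds below may be only part of what the source reports. "The series", "measured", "known", "first", "only" and "open" are said of these compounds alone.

Three compounds built on one shared core have been through an ADME assay (MDM cells, Homo sapiens) for cytotoxicity, read by resazurin assay, with a stated time of 3 days; a lower number here means a stronger inhibitor, a higher number a weaker inhibitor. Compound 1 `CCOC(=O)CSc1nnc(COc2ccccc2C2=NOC(c3ccc(Cl)cc3Cl)C2)n1NC(=O)c1ccccc1` has the outcome "not determined" (no result reported). Compound 2 `O=C(Nn1c(COc2ccccc2C2=NOC(c3ccc(Cl)cc3Cl)C2)nnc1Sc1ccccc1)c1ccccc1` likewise shows "not determined" (no result reported). Only compound 3 `CSc1nnc(COc2ccccc2C2=NOC(c3ccc(Cl)cc3Cl)C2)n1NC(=O)CCl` carries a number: in this assay compound 3 gives 2.7 ug/mL, and with nothing else measured it stands alone, neither strong nor weak by comparison. Compound 4 `CSc1nnc(COc2ccccc2C2=NOC(c3ccc(Cl)cc3Cl)C2)n1NC(=O)c1ccccc1` differs from compound 3 in a single place: phenyl in place of chloromethyl on a carbonyl carbon. Within the data shown here, no pair of measured compounds shows what such a change does in this assay, so the size of the step rests on expectation only. The step of a 3.7-fold higher number from compound 3 to compound 4 (0.57 log units; beyond the scatter) is expected to run toward a weaker inhibitor and to exceed the usual scatter. Compound 4 is therefore expected to read 10 ug/mL, estimated between 3 ug/mL and 40 ug/mL.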

Compound 4, half-maximal inhibitory concentration: 2.2 ug/mL
Beside the measured number, compound 4's estimate is 4.5-fold (0.66 log units) above it; measured number outside the range, below it.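

In this assay, putting phenyl in place of chloromethyl on this carbonyl carbon gives a 1.2-fold lower number from compound 3 to compound 4 (0.09 log units; within the scatter), so the two compounds cannot be told apart. At this position, then, a six-membered aromatic ring of carbon and a small chlorine-bearing group read alike, which a single number could not show. Nothing measured here explains this match.

This rests on one pair of compounds, so it is no general rule for the position. Going by these compounds, whether an amine or a longer carbon chain on the same carbonyl carbon would also read alike remains open.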